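This account rests on a few compounds, and the source may have more. Where it says the series, first, only, none or still open, it means among the compounds named here.

Measured compounds in an assay on isolated protein for inhibition of alpha-galactosidase (Coffea arabica); on this read-out lower numbers stand for stronger inhibition and higher numbers for weaker inhibition:
compound 1 `O=C(Nc1ccccc1)O/N=C1\N[C@H](CO)[C@@H](O)[C@H](O)[C@H]1O`: the value reported for compound 1 is a limit of the assay, > 100000 nM.
compound 2 `O=C(Nc1cccc2ccccc12)O/N=C1\N[C@H](CO)[C@@H](O)[C@H](O)[C@H]1O`: the value reported for compound 2 is likewise a limit of the assay, > 100000 nM.

Compound 1 thus stands at the upper boundary of what this assay can report, and it is not alone there: both values shown sit at the same limit (the limit of > 100000 nM in this assay, at which 2 of the 2 values shown sit), so no ordering between compound 1 and compound 2 can be drawn from these numbers.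

The unmeasured compound 3 `O=C(Nc1ccc(Oc2ccccc2)cc1)O/N=C1\N[C@H](CO)[C@@H](O)[C@H](O)[C@H]1O` differs from compound 1 at a single place: phenoxy in place of hydrogen on an aromatic carbon, a phenoxy group in place of a hydrogen atom on an aromatic carbon, para to a large group. Among the measured compounds shown here, no measured step between compounds that differ in one place exists, so the size of the step has to be judged from the limits alone. With both values at the limit, a step in either direction beyond the scatter is not expected.

In this assay compound 3 is therefore estimated at 150000 nM, within 30000 nM to 1000000 nM, which is expected to mean a step that the limit leaves unreadable from compound 1 to compound 3.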

Compound 3, half-maximal inhibitory concentration: > 100000 nM
Compound 3 was reported as a limit; the forecaster's own chance of this, stated with the estimate: 75%; the middle value lies beyond the limit too.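

In this assay compound 3 gives > 100000 nM, which is a limit of the assay, so no step from compound 1 to compound 3 can be read: the limit of > 100000 nM in this assay, at which 3 of the 3 values shown sit.

The compounds shown leave open whether any change to the shared core would bring a value within what this assay can report, and what effect phenoxy in place of hydrogen has on inhibition.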